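Placing a Hydroxy Group on the Piperidine Ring

The source may report more compounds than this note shows. Statements on the series, on what has been measured and on what is new or still open speak of the compounds shown alone.

Measured in an assay on isolated protein (Cavia porcellus) with Sigma non-opioid intracellular receptor 1 (Homo sapiens) as the target, read by radioligand binding; a higher number here means a weaker inhibitor, a lower number a stronger inhibitor:
compound 1, `CN(C)CCCCCCCOc1ccc2oc(-c3ccccc3)cc(=O)c2c1`, gives 188 nM
compound 2, `O=c1cc(-c2ccccc2)oc2ccc(OCCCCCCN3CCCCC3)cc12`, gives 54 nM

Compound 2 holds the lowest of the two numbers in this assay; its nearest neighbour is compound 1, and the change between them is a 3.5-fold lower number from compound 1 to compound 2 (0.54 log units; beyond the scatter), a swap of the amine at the end of the chain. Compound 3, `O=c1cc(-c2ccccc2)oc2ccc(OCCCCCCN3CCCC(O)C3)cc12`, is not yet measured. It differs from compound 2 only in the change (hydroxy in place of hydrogen on a saturated ring carbon), which reads as piperidin-1-yl to 3-hydroxypiperidin-1-yl. Within the data shown here, no measured step touches this kind of change: the single step known here exchanges one amine for another and says nothing about decorating the piperidine ring itself. The expectation for compound 3 therefore rests on little more than the value of compound 2 in this assay, with a modest allowance for a weakening, so that the estimated step is a 1.7-fold higher number from compound 2 to compound 3 (0.22 log units; within the scatter). Compound 3 is thus expected to give about 90 nM in this assay, within a range from 30 nM to 270 nM.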

Compound 3, half-maximal inhibitory concentration: 77 nM
Estimate against measurement, compound 3: 1.2-fold (0.07 log units) above, within the range that was stated.
By their numbers in this assay, from the lowest: compounds 2 and 3 (each within the scatter of the next); then compound 1.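

In this assay, the piperidine ring of compound 2 accepts a hydroxy group on a saturated ring carbon, two ring bonds from the ring nitrogen, and the result is a 1.4-fold higher number from compound 2 to compound 3 (0.15 log units; within the scatter), so compound 2 and compound 3 cannot be told apart at this place. The earlier pair showed only an exchange of one amine for another, a 3.5-fold lower number from compound 1 to compound 2 (0.54 log units; beyond the scatter), and the new compound shows that a separation from the dimethylamino compound remains once the ring carries the hydroxy group, at a 2.4-fold lower number from compound 1 to compound 3 (0.39 log units; beyond the scatter). Nothing available here explains why the added oxygen leaves the number within the scatter, and no outside measurement bears on this result.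

This single substitution cannot show whether the tolerance belongs to the hydroxy group itself or extends to other groups, such as a methoxy group, a fluorine atom or a carboxylic acid on the same saturated ring carbon. As far as these compounds go, whether the same tolerance would hold with a shorter or longer chain between the ring nitrogen and the oxygen on the aromatic ring also remains open.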